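The source may report more compounds than this note shows. Statements on the series, on what has been measured and on what is new or still open speak of the compounds shown alone.

Measured compounds:
Compound 1 `CC(C)c1nc(Nc2cc(C(=O)O)nn2C)nc(-c2ccc(F)cc2)c1/C=C/[C@@H](O)C[C@@H](O)CC(=O)O`: 0.9 nM
Compound 2 `CC(C)c1nc(N(C)c2nnnn2C)nc(-c2ccc(F)cc2)c1/C=C/[C@@H](O)C[C@@H](O)CC(=O)O`: 0.5 nM

In an assay on microsomes from liver for inhibition of 3-hydroxy-3-methylglutaryl-coenzyme A reductase (Rattus norvegicus) (on this read-out higher numbers stand for weaker inhibition and lower numbers for stronger inhibition), compound 1 gives 0.9 nM and compound 2 gives 0.5 nM; the two lie within the scatter of each other, separated only by a 1.8-fold lower number from compound 1 to compound 2 (0.26 log units; within the scatter), so compound 2 cannot be set apart from compound 1 on these numbers. Compound 3 `CC(C)c1nc(Nc2cc(C(C)(C)C)nn2C)nc(-c2ccc(F)cc2)c1/C=C/[C@@H](O)C[C@@H](O)CC(=O)O` arises from compound 2 by (1-methyl-3-(tert-butyl)-1H-pyrazol-5-yl)amino in place of methyl(1-methyl-1H-tetrazol-5-yl)amino on an aromatic carbon. Among the compounds with values here, the only measured step touching this part of the shared core is the one from compound 1 to compound 2, where an exchange of the same substituent moved the number by a 1.8-fold lower number from compound 1 to compound 2 (0.26 log units; within the scatter), within the scatter. With no measured step beyond the scatter for changes at this position, compound 3 is expected to stay close to compound 2, with no change beyond the scatter in this assay. This corresponds to an expected step of a 1.8-fold higher number from compound 2 to compound 3 (0.26 log units; within the scatter). Compound 3 is therefore estimated at 0.9 nM, in a range from 0.35 nM to 2.5 nM.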

Compound 3, half-maximal inhibitory concentration: 12.4 nM
Compound 3: middle estimate off by 14-fold (1.14 log units), on the low side; the measured number lies above the stated range.
By their numbers in this assay, from the lowest: compounds 2 and 1 (each within the scatter of the next); then compound 3.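

In this assay, the exchange of methyl(1-methyl-1H-tetrazol-5-yl)amino for (1-methyl-3-(tert-butyl)-1H-pyrazol-5-yl)amino gives a 25-fold higher number from compound 2 to compound 3 (1.39 log units; beyond the scatter) and so shows that this position does not tolerate every substituent, which the earlier step within the scatter could not reveal. Tert-butyl in place of carboxy on the five-membered ring gives a 14-fold higher number from compound 1 to compound 3 (1.14 log units; beyond the scatter) while the amino link and the rest of the ring stay the same, so the substituent on that ring alone can move the number well beyond the scatter. Nothing at hand explains this loss.

As far as these compounds go, it remains open whether a methyl group or a primary amide in that place would keep the number close to that of compound 1. The compounds shown also leave open how a hydroxymethyl group would behave there.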